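Working notes: the step from compound 1 to compound 4

A few compounds are considered here, and "the series" means these few. Any claim that something is new, unique, unknown or untested is made for them only; others in the source may bear on it.

Measured so far in a functional assay on HL-60 cells (Homo sapiens) for inhibition, read by MTT assay, with a stated time of 72 h, tested at 50 uM; on this read-out higher numbers stand for more inhibition of growth at the one concentration tested and lower numbers for less inhibition of growth:
- compound 1 `C=CCc1cc(O)c(O)c(CN2CCC(C)CC2)c1`: 91.8%
- compound 2 `C=CCc1ccc(OCc2cn(-c3ccccc3Cl)nn2)c(O)c1`: 43.2%
- compound 3 `C=CCc1ccc(OCc2cn(-c3ccc(OC)cc3)nn2)c(O)c1`: 38.9%

Compound 1 stands highest of the three, and its gaps to compound 2 and compound 3 both lie beyond the scatter. Not yet measured is compound 4 `C=CCc1cc(O)c(O)c(CN2CCC(CO)CC2)c1`. The change from compound 1 is hydroxy in place of hydrogen on a saturated chain carbon bound to a saturated ring carbon, which can also be read as methyl to hydroxymethyl.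

Going by the values given here, the only measured step, a number 4.3 percentage points lower from compound 2 to compound 3 (within the scatter), lies within the scatter. It concerns a substituent on an aromatic nitrogen, not a saturated chain carbon, so it bears only weakly on this change. Among the compounds with values here, no measured pair shows the effect of this change directly. Compound 1 at 91.8% leaves little room above it, so any shift in this assay is expected to be downward. The expected step, a number 7.8 percentage points lower from compound 1 to compound 4 (within the scatter), is small and not expected to exceed the scatter. Compound 4 is estimated at 84%. The expected range runs from 62% to 98%.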

Compound 4, percent growth inhibition at one concentration: 43.3%
Compound 4: the middle estimate sits 40.7 percentage points above what was measured; measured number outside the range, below it.
By their numbers in this assay, from the lowest: compounds 3, 2 and 4 (each within the scatter of the next); then compound 1.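

In this assay, the series shows a number 48.5 percentage points lower from compound 1 to compound 4 (beyond the scatter) for hydroxy in place of hydrogen on a saturated chain carbon bound to a saturated ring carbon, a change of only 1 heavy atom. Going by these compounds alone, the one earlier step between compounds differing in one place stayed within the scatter and concerned a substituent on an aromatic nitrogen, so this is the first sign that the series can respond strongly to a small change, and that this position is sensitive to it. Nothing at hand accounts for the size of this step.

From the compounds shown here alone, it remains open whether the drop is specific to hydroxymethyl or would also appear with a methoxymethyl, an aminomethyl, a carboxylic acid or a longer chain such as ethyl at this place. The compounds shown also leave open whether any group here can match the growth inhibition of methyl.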